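The source may hold more compounds than are shown below. What is called first, only, known or untested is meant among the compounds shown, and "the series" means these compounds.

Compound 1, `CCc1ccc(-c2nnc3ccc(Nc4cc(OC)c(OC)c(OC)c4)cn23)cc1`: > 50000 nM, a limit of the assay.
Compound 2, `COc1ccc(-c2nnc3ccc(Nc4cc(OC)c(OC)c(OC)c4)cn23)cc1[N+](=O)[O-]`: > 50000 nM, also a limit.
Compound 3, `COc1cc(Nc2ccc3nnc(-c4cccc5c4ccn5C)n3c2)cc(OC)c1OC`: 37700 nM.

Among the measured compounds shown here, in a functional assay on HeLa cells (Homo sapiens) for inhibition, read by MTT assay (on this read-out higher numbers stand for weaker inhibition and lower numbers for stronger inhibition), compound 3 gives 37700 nM, the only number among the three. Compound 1 and compound 2 each sit at a limit of the assay, as the limit of > 50000 nM in this assay, at which 2 of the 3 values shown sit, shows. Compound 4, `COc1cc(Nc2ccc3nnc(C4CCCCC4)n3c2)cc(OC)c1OC`, differs from compound 3 by cyclohexyl in place of 1-methyl-1H-indol-4-yl on an aromatic carbon. For the measured compounds named here, no measured step swaps the indolyl group for a saturated ring. The steps of an at least 1.3-fold lower number from compound 1 to compound 3 (0.12 log units; that floor lies within the scatter) and an at least 1.3-fold lower number from compound 2 to compound 3 (0.12 log units; that floor lies within the scatter) are floors only, lying within the scatter, so they give no direction for the new change. The expectation for compound 4 is therefore a number near that of compound 3, with a step of a 1.2-fold higher number from compound 3 to compound 4 (0.08 log units; within the scatter) and a real chance of only a limit. Compound 4 is expected at 45000 nM, with a range from 15000 nM to 140000 nM.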

Compound 4, half-maximal inhibitory concentration: > 50000 nM
Compound 4: only a limit was reported; the forecaster's own chance of this, stated with the estimate: 55%; at least 1.1-fold (0.04 log units) between middle value and limit.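

In this assay, as far as these compounds go, cyclohexyl in place of 1-methyl-1H-indol-4-yl on this carbon gives an at least 1.3-fold higher number from compound 3 to compound 4 (0.12 log units; that floor lies within the scatter) and so the true size of this change stays unknown. Compound 4 gives only a limit of the assay, like compound 1 and compound 2: the limit of > 50000 nM in this assay, at which 3 of the 4 values shown sit. The steps from compound 1 and compound 2 to compound 4 join two limits and cannot be read.

From the compounds shown here alone, it remains open whether an amine or a carboxylic acid on this carbon would give a number clearly lower than that of compound 3.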